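Chloro in place of hydrogen on compound 1

A few compounds are considered here, and "the series" means these few. Any claim that something is new, unique, unknown or untested is made for them only; others in the source may bear on it.

Compound 1 `C[S+]([O-])/C=C/c1cc(=O)c2ccccc2o1` gives 8000 nM here
Compound 2 `COc1cccc2oc(/C=C/[S+](C)[O-])cc(=O)c12` gives > 10000 nM here, which is a limit

Going by the values given here, in a functional assay on DLD-1 cells (Homo sapiens) for cytotoxicity, with a stated time of 48 h (a higher number here means a weaker inhibitor, a lower number a stronger inhibitor), compound 1 holds the only actual number so far, at 8000 nM on this read-out. Compound 2 is reported only as a limit, > 10000 nM in this case.

Compound 3 `C[S+]([O-])/C=C/c1cc(=O)c2cc(Cl)ccc2o1` departs from compound 1 by a single change: chloro in place of hydrogen on an aromatic carbon.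

Among the compounds with values here, one measured step bears on it: an at least 1.2-fold higher number from compound 1 to compound 2 (0.09 log units; that floor lies within the scatter), with methoxy in place of hydrogen on an aromatic carbon. Its far end rests on (the limit of > 10000 nM in this assay, at which 1 of the 2 values shown sits), so it offers a floor within the scatter and no firm size. No step beyond the scatter is therefore expected in this assay in either direction. The estimated change is a 1.2-fold lower number from compound 1 to compound 3 (0.09 log units; within the scatter), and the range is kept wide. Compound 3 is estimated at 6500 nM, with 2500 nM to 14000 nM as the expected range.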

Compound 3, half-maximal inhibitory concentration: 6500 nM
Estimate against measurement, compound 3: no gap at the digits printed; the range from low to high includes it.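

In this assay, chloro in place of hydrogen on this aromatic carbon, meta to a fused ring and para to a fused ring, gives a 1.2-fold lower number from compound 1 to compound 3 (0.09 log units; within the scatter). Unlike the methoxy comparison, this step has actual numbers at both ends, so its size is measured and not merely bounded, and it shows that a single chlorine here leaves the read-out within the scatter of compound 1. Compound 2 remains a limit, so the chloro and methoxy changes cannot be ranked against each other: the limit of > 10000 nM in this assay, at which 1 of the 3 values shown sits.

As far as these compounds go, whether any group at this position can move the read-out beyond the scatter remains open. An amine, a carboxylic acid or a longer chain here would test that, as would chloro on another aromatic carbon of the shared core.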